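The compounds below may be only part of what the source reports. "The series", "measured", "known", "first", "only" and "open" are said of these compounds alone.

Two compounds of the series have been taken through a physicochemical assay for solubility, with a stated time of 18 h, at pH 7.4; on this read-out higher numbers stand for higher solubility and lower numbers for lower solubility. Compound 1 `FC(F)(F)c1ccc(-c2ccc3c(NCCCNCc4ccco4)ccnc3c2)cc1` gives 32000 nM. Compound 2 `COc1ccc(F)cc1CNCCCNc1ccnc2cc(-c3cccc4ccccc34)ccc12` gives 32000 nM, level with compound 1 at the digits read, within the scatter. Compound 3 `c1coc(CNCCCNc2ccnc3cc(-c4cccc5ccccc45)ccc23)c1` is the next member: the change from compound 2 is furan-2-yl in place of 5-fluoro-2-methoxyphenyl on a saturated chain carbon bound to an amine nitrogen, the same difference one bond further out reading 5-fluoro-2-methoxybenzyl to (furan-2-yl)methyl. Among the measured compounds shown here, with no measured pair of this kind to lean on, the expected step from compound 2 is small, if any, in either direction, as no change at the digits printed from compound 2 to compound 3 (within the scatter). For compound 3 the estimate in this assay is 32000 nM, within 16000 nM to 64000 nM.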

Compound 3, solubility: 32000 nM
For compound 3 middle estimate and measured number coincide at the digits printed; the measured number falls inside the stated range.
By their numbers in this assay, from the lowest: compounds 1, 2 and 3 (each within the scatter of the next).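

Two single changes can now be read in one assay (this assay): furan-2-yl in place of 5-fluoro-2-methoxyphenyl on a saturated chain carbon bound to an amine nitrogen (no change at the digits printed from compound 2 to compound 3 (within the scatter)), and naphthalen-1-yl in place of 4-(trifluoromethyl)phenyl on an aromatic carbon (no change at the digits printed from compound 1 to compound 3 (within the scatter)). Neither place has yet shown a step beyond the scatter with these groups. No measurement at hand bears on the cause of these readings.

On these data alone, whether a carboxylic acid or a morpholine at either place would give a step beyond the scatter remains open. So does the outcome with a longer chain.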